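Swapping the Methoxy Ring for a Hydroxy Ring

The compounds below may be only part of what the source reports. "The series", "measured", "known", "first", "only" and "open" are said of these compounds alone.

Compound 1 `COc1ccc(-c2nc3cccc(-c4cc(OC)c(OC)c(OC)c4)c3o2)cc1` carries a trimethoxyphenyl group on one side of its shared core and a 4-methoxyphenyl group on the other. Among the compounds with values here, in a functional assay on A549 cells (Homo sapiens) for antiproliferative activity, read by MTT assay, with a stated time of 48 h (on this read-out higher numbers stand for weaker inhibition and lower numbers for stronger inhibition), compound 1 gives 2200 nM, the second highest of the three numbers so far. Compound 2 `COc1ccc(-c2nc3cccc(-c4cc(OC)c(OC)c(OC)c4)c3o2)cc1F` gives 1800 nM, and a 1.2-fold lower number from compound 1 to compound 2 (0.09 log units; within the scatter). Compound 3 `COc1cc(-c2cccc3nc(-c4ccc(Cl)cc4)oc23)cc(OC)c1OC` gives 5600 nM, and a 2.5-fold higher number from compound 1 to compound 3 (0.41 log units; beyond the scatter).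

Compound 4 `COc1cc(-c2cccc3nc(-c4cccc(O)c4)oc23)cc(OC)c1OC` differs from compound 1 in one place: 3-hydroxyphenyl in place of 4-methoxyphenyl on an aromatic carbon. Within the data shown here, no measured step shows a hydroxyl entering, so the closest guide is the step from compound 1 to compound 3, where removing the methoxy group on this ring cost activity modestly. The step from compound 1 to compound 2 shows that a small change elsewhere on the same ring stayed within the scatter. On that basis a modest weakening is expected for compound 4 in this assay, with a 1.6-fold higher number from compound 1 to compound 4 (0.20 log units; within the scatter). Compound 4 is therefore estimated at 3500 nM, with a plausible range from 900 nM to 14000 nM.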

Compound 4, half-maximal inhibitory concentration: 2000 nM
Beside the measured number, compound 4's estimate is 1.8-fold (0.24 log units) above it; measured number inside the range.
By their numbers in this assay, from the lowest: compounds 2, 4 and 1 (each within the scatter of the next); then compound 3.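

In this assay, the 3-hydroxyphenyl group and the 4-methoxyphenyl group cannot be told apart, with a 1.1-fold lower number from compound 1 to compound 4 (0.04 log units; within the scatter) for this swap, and the same holds against the 3-fluoro-4-methoxyphenyl group, with a 1.1-fold higher number from compound 2 to compound 4 (0.05 log units; within the scatter) for that one. The 4-chlorophenyl group alone stands apart, with a 2.8-fold lower number from compound 3 to compound 4 (0.45 log units; beyond the scatter) on going to the hydroxy ring, so a ring without a methoxy group can still match compound 1 and losing the methoxy group does not by itself raise the number. Nothing available explains why these groups compare as they do.

The compounds shown leave open whether the hydroxyl's place on the ring matters, as a 4-hydroxyphenyl group is not among them. They also leave open how an amine or a carboxylic acid on this ring would compare.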